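The compounds below may be only part of what the source reports. "The series", "measured", "known", "first", "only" and "open" are said of these compounds alone.

Compound 1 `CCN(CC)CN1C(=O)/C(=N/NC(=S)Nc2ccc(OC)cc2)c2cc(Cl)ccc21`: in an ADME assay on MDCK cells (Canis lupus familiaris) for cytotoxicity (a higher number here means that more compound is tolerated, a lower number that less compound is tolerated), compound 1 gives a value that is a limit of the assay, >= 800 nM.
Compound 2 `CCN(CC)CN1C(=O)/C(=N/NC(=S)Nc2ccc(C)cc2)c2cc(Cl)ccc21`: in this assay compound 2 gives 4000 nM.

Among the values shown for this assay, compound 2 holds the only true number; the one further value is a limit. The step that the limit leaves unreadable from compound 1 to compound 2, methyl in place of methoxy on an aromatic carbon, has no readable size because of the limit of >= 800 nM in this assay, at which 1 of the 2 values shown sits.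

Compound 3 `CCN(CC)CN1C(=O)/C(=N/NC(=S)Nc2ccc(Cl)cc2)c2cc(Cl)ccc21` differs from compound 2 by chloro in place of methyl on an aromatic carbon. For the measured compounds named here, no measured step concerns chloro in place of methyl on an aromatic carbon, and the single measured step offers no size to lean on. Compound 3 is therefore expected to stand near compound 2, with an expected step of no change at the digits printed from compound 2 to compound 3 (within the scatter) that stays within the scatter. For compound 3 the estimate in this assay is 4000 nM, with a range from 1500 nM to 10000 nM.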

Compound 3, minimum cytotoxic concentration: >= 800 nM
Compound 3 was reported as a limit; the forecaster's own chance of this, stated with the estimate: 25%; the middle value is on the limit's open side.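

In this assay compound 3 gives >= 800 nM, which is a limit. No new step can be read between compound 3 and either compound 1 or compound 2: the limit of >= 800 nM in this assay, at which 2 of the 3 values shown sit.

The compounds shown leave open how far the tolerated concentration differs among the methoxy, methyl and chloro groups on the aromatic carbon.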